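Sulfonyl substituent change on a pyrazoline core

A few compounds are considered here, and "the series" means these few. Any claim that something is new, unique, unknown or untested is made for them only; others in the source may bear on it.

Compound 1 `CN(C)c1ccc(C2CC(c3ccc(-n4ccnc4)cc3)=NN2C(=O)c2cc(Cl)cc(Cl)c2)cc1` gives 48.8% in a functional assay on MDA-MB-231 cells (Homo sapiens) for inhibition, read by sulforhodamine B assay, tested at 10 uM (a lower number here means less inhibition, a higher number more inhibition at the concentration tested (going by the name of the read-out)), and compound 2 `CN(C)c1ccc(C2CC(c3ccc(-n4ccnc4)cc3)=NN2S(C)(=O)=O)cc1` gives 12%. Going by the values given here, the one measured step, a number 36.8 percentage points lower from compound 1 to compound 2 (beyond the scatter), was large, and compound 2 therefore stands lowest of the two numbers, with compound 1 its only neighbour and well beyond the scatter above it.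

Compound 3 `Cc1ccc(S(=O)(=O)N2N=C(c3ccc(-n4ccnc4)cc3)CC2c2ccc(N(C)C)cc2)cc1` differs from compound 2 by 4-methylphenyl in place of methyl on a sulfonyl sulfur. Among the compounds with values here, no measured step changes the substituent on the sulfonyl sulfur, so nothing bears on it directly. The step from compound 1 to compound 2 only shows that the group on the ring nitrogen matters a great deal: removing an aromatic ring there together with the carbonyl cost much inhibition. Compound 3 returns an aromatic ring to that position, now on the sulfonyl sulfur, which suggests a rise rather than a fall, but of uncertain size.

Compound 3 is therefore expected to give 30% in this assay, within a range of 8% to 55%, an expected step of a number 18 percentage points higher from compound 2 to compound 3 (beyond the scatter).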

Compound 3, a percentage reported as inhibition, at one concentration (the size of the read-out at that concentration, not a potency): 50.8%
Compound 3: middle estimate off by 20.8 percentage points, on the low side; measured number inside the range.
By their numbers in this assay, from the lowest: compound 2; then compounds 1 and 3 (each within the scatter of the next).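

With the sulfonyl kept on the ring nitrogen, the change in this assay is a number 38.8 percentage points higher from compound 2 to compound 3 (beyond the scatter) and so the low number of compound 2 goes with the methyl on the sulfur, not with the sulfonyl as such. The step to the carbonyl-bearing compound is a number 2 percentage points higher from compound 1 to compound 3 (within the scatter) and this shows that, among these compounds, a carbonyl on this amine nitrogen in a ring is not needed to reach that level of inhibition, although the two groups differ in more than the linking atom, so the comparison does not isolate the sulfonyl from the carbonyl. No measured evidence is available to explain either step.

From the compounds shown here alone, what remains open is whether the aromatic ring itself matters or whether other groups on the sulfonyl sulfur would serve equally, such as a cyclohexyl ring or a longer alkyl chain. The part played by the methyl on the ring is also unsettled, and plain phenyl, or a ring carrying a methoxy group, an amine or a carboxylic acid, would address it.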